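Carboxylate in place of the primary amide on the shared core

The compounds below may be only part of what the source reports. "The series", "measured", "known", "first", "only" and "open" are said of these compounds alone.

Compound 1 `N#Cc1c(-c2ccc(Br)cc2)nc2cnccc2c1NCC(N)=O`: 1.9
Compound 2 `CC[C@@H](Nc1c(C#N)c(-c2ccc(-c3cccc(OC)c3)cc2)nc2cnccc12)C(N)=O`: 2.7

In a physicochemical assay for lipophilicity, read by HPLC, at pH 7.5 (a lower number here means a more polar compound, a higher number a more lipophilic compound), compound 1 gives 1.9, the lowest of the two numbers. For the measured compounds named here, compound 2 gives 2.7, a gap beyond the scatter; no single-point step connects compound 1 to compound 2, so only the two values themselves are on record.

Compound 3 `CC[C@@H](Nc1c(C#N)c(-c2ccc(Br)cc2)nc2cnccc12)C(=O)O` is not yet measured. It differs from compound 1 as 1-carboxypropyl in place of carbamoylmethyl on a nitrogen on an aromatic ring. Going by the values given here, no measured step in this assay covers such a change, so the expectation rests on compound 1 alone. A downward step is expected, estimated as a number 0.90 log units lower from compound 1 to compound 3 (beyond the scatter). Compound 3 is expected to give about 1 in this assay, within 0 to 2.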

Compound 3, distribution coefficient: 1.6
Beside the measured number, compound 3's estimate is 0.60 log units below it; the measured number falls inside the stated range.
By their numbers in this assay, from the lowest: compounds 3 and 1 (each within the scatter of the next); then compound 2.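

In this assay, 1-carboxypropyl in place of carbamoylmethyl on a nitrogen on an aromatic ring gives a number 0.30 log units lower from compound 1 to compound 3 (within the scatter), the first step recorded at this position. This single change swaps the primary amide for a carboxylic acid and also brings a longer chain and a defined stereocentre, so the step cannot be divided among these parts. No measurement on record accounts for this step.

Still open, going by these compounds, is how carboxymethyl on the same nitrogen would read, which would separate the acid from the longer chain. An amine at this position also remains an open comparison on the shared core.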